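Replacing Cyano with Ethoxycarbonyl in Compound 2

This account rests on a few compounds, and the source may have more. Where it says the series, first, only, none or still open, it means among the compounds named here.

In an ADME assay on MDBK cells (Bos taurus) for cytotoxicity, read by MTT assay, with a stated time of 96 h (a higher number here means that more compound is tolerated, a lower number that less compound is tolerated), compound 1 (`FC(F)(F)c1cccc(NC(=S)Nc2ccc(Cl)cc2)c1`) gives 17000 nM and compound 2 (`N#Cc1ccc(NC(=S)Nc2cccc(C(F)(F)F)c2)cc1`) gives 10000 nM as its reading. These two share a core and differ at one aromatic carbon, where cyano stands in place of chloro. Among the compounds with values here, that swap gives a 1.7-fold lower number from compound 1 to compound 2 (0.23 log units; within the scatter) as the only measured step, so compound 2 cannot be told apart from compound 1 on these numbers.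

Compound 3 (`CCOC(=O)c1ccc(NC(=S)Nc2cccc(C(F)(F)F)c2)cc1`) keeps the core of compound 2 and changes that same aromatic carbon, with ethoxycarbonyl in place of cyano. The change in full reads: ethoxycarbonyl in place of cyano on an aromatic carbon and nothing else differs. Within the data shown here, no compound carrying ethoxycarbonyl has been measured, so the one guide is the small step between compound 1 and compound 2 already described. It offers no direction, and no step beyond the scatter is expected in this assay for this change. The expected step is a 1.2-fold higher number from compound 2 to compound 3 (0.08 log units; within the scatter) on this estimate. For compound 3 the estimated value is 12000 nM with an expected range from 5000 nM to 30000 nM around it.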

Compound 3, half-maximal cytotoxic concentration: 64000 nM
The estimate for compound 3 lay 5.3-fold (0.73 log units) below the measured number; the whole stated range lies below it.
By their numbers in this assay, from the lowest: compounds 2 and 1 (each within the scatter of the next); then compound 3.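

In this assay this aromatic carbon, para to a large group, proves not to be indifferent to what it carries: chloro and cyano could not be told apart, yet ethoxycarbonyl in place of cyano gives a 6.4-fold higher number from compound 2 to compound 3 (0.81 log units; beyond the scatter) and ethoxycarbonyl in place of chloro gives a 3.8-fold higher number from compound 1 to compound 3 (0.58 log units; beyond the scatter) in the same direction. Both steps are modest, but together they set compound 3 apart from the other two, so on this core more compound is tolerated with ethoxycarbonyl at this carbon than with either earlier group. Nothing available here accounts for this difference, which stands only as an observation on these three compounds.

As far as these compounds go, what stays open is which part of ethoxycarbonyl goes with the higher number, the carbonyl or the ethyl chain attached through oxygen, since a carboxylic acid, a methoxycarbonyl group or a longer chain on the same oxygen would be needed to separate them. From the compounds shown here alone, it is also open whether the same step would appear with a group other than trifluoromethyl on the second aromatic ring, because all three compounds share that group.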